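Indol-4-yl oxygen linker replacing 2-methylphenyl on the shared core

The compounds below may be only part of what the source reports. "The series", "measured", "known", "first", "only" and "open" are said of these compounds alone.

Among the measured compounds shown here, compound 1 `Cc1ccccc1OC1CCN(c2ccc(-n3ccnc3)nn2)CC1` gives 39 nM in an assay on microsomes from liver for inhibition of acyl-CoA desaturase 1 (Rattus norvegicus) (on this read-out lower numbers stand for stronger inhibition and higher numbers for weaker inhibition), the lowest of the two numbers measured so far. Its nearest neighbour is compound 2 `Cc1ccc(OC2CCN(c3ccc(-n4ccnc4)nn3)CC2)cc1` with 527 nM; the step of a 14-fold higher number from compound 1 to compound 2 (1.13 log units; beyond the scatter) is large and comes from moving a single methyl group around the ring on the oxygen.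

Compound 3 `c1cc(OC2CCN(c3ccc(-n4ccnc4)nn3)CC2)c2cc[nH]c2c1` differs from compound 1 as follows: 1H-indol-4-yl in place of 2-methylphenyl on an oxygen on a saturated carbon. For the measured compounds named here, the only measured step, from compound 1 to compound 2, shows that this part of the molecule governs the read-out strongly, yet it tests a methyl shift, not an exchange for a fused bicyclic ring bearing a hydrogen-bond donor. Going by the values given here, no measured pair bears directly on the new ring. Given the sensitivity seen in a 14-fold higher number from compound 1 to compound 2 (1.13 log units; beyond the scatter), a shift beyond the scatter in either direction is possible; the estimate for compound 3 leans toward a modest weakening, a 1.8-fold higher number from compound 1 to compound 3 (0.25 log units; within the scatter), with wide uncertainty. Compound 3 is therefore expected at about 70 nM in this assay, within a range of 15 nM to 350 nM.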

Compound 3, half-maximal inhibitory concentration: 162 nM
For compound 3 the middle estimate is 2.3-fold (0.36 log units) below the measured one; low and high end bracket the measured number.
By their numbers in this assay, from the lowest: compound 1; then compound 3; then compound 2.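

In this assay, 1H-indol-4-yl in place of 2-methylphenyl on the oxygen gives a 4.2-fold higher number from compound 1 to compound 3 (0.62 log units; beyond the scatter), while the same group in place of 4-methylphenyl gives a 3.3-fold lower number from compound 2 to compound 3 (0.51 log units; beyond the scatter), so the new group lands inside the range set by the two methylphenyl compounds and both steps lie beyond the scatter. This position therefore accepts a fused two-ring aromatic group with 9 heavy atoms and a hydrogen-bond donor in place of a single ring with 7 heavy atoms, and the exchange from compound 1 moves the number less than the methyl shift alone did in a 14-fold higher number from compound 1 to compound 2 (1.13 log units; beyond the scatter) on the shared core. Nothing available explains why compound 3 falls where it does.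

The compounds shown leave open whether the hydrogen-bond donor of 1H-indol-4-yl matters to the read-out at all, a question that a methyl group on the indole nitrogen would address directly. They also leave open how a methoxy group or a chlorine atom in place of the methyl of 2-methylphenyl would compare with compound 1.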